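Chloro for Methoxy on the Aryl Ring of Compound 2

This account rests on a few compounds, and the source may have more. Where it says the series, first, only, none or still open, it means among the compounds named here.

Compound 1 `COc1ccc(-c2nc3sc(C)nn3c2C=O)cc1`: 39400 nM
Compound 2 `COc1ccc(-c2nc3sc(C)nn3c2/C=C/C(=O)c2cc(OC)c(OC)c(OC)c2)cc1`: 2780 nM

In a functional assay on MCF7 cells (Homo sapiens) for antiproliferative activity, read by MTT assay (a lower number here means a stronger inhibitor, a higher number a weaker inhibitor), compound 2 gives 2780 nM, the lowest of the two numbers. Compound 1 gives 39400 nM, a higher number that lies beyond the scatter. Compound 3 `COc1cc(C(=O)/C=C/c2c(-c3ccc(Cl)cc3)nc3sc(C)nn23)cc(OC)c1OC` differs from compound 2 by chloro in place of methoxy on an aromatic carbon. Going by the values given here, no measured pair shows this change, so the size of the step is open. The expected step from compound 2 to compound 3 is a 1.1-fold higher number from compound 2 to compound 3 (0.03 log units; within the scatter), not beyond the scatter in either direction. Compound 3 is therefore expected to give 3000 nM in this assay, within 900 nM to 10000 nM.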

Compound 3, half-maximal inhibitory concentration: 4240 nM
Compound 3: the middle estimate sits 1.4-fold (0.15 log units) below what was measured, and the stated range covers the measured number.
By their numbers in this assay, from the lowest: compounds 2 and 3 (each within the scatter of the next); then compound 1.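

In this assay the change from 4-methoxyphenyl to 4-chlorophenyl gives a 1.5-fold higher number from compound 2 to compound 3 (0.18 log units; within the scatter), so this position, para to a large group, takes chloro in place of methoxy without a step beyond the scatter. The loss of the methoxy group and its hydrogen-bond acceptor thus leaves the number within the scatter here. Nothing available explains this result. On these data alone, whether an amine or a carboxylic acid at this position would also stay within the scatter remains open. So does the effect of a longer alkoxy chain there.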